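Swapping a Nitrile for Isopropyl on the Arylpiperazine

A few compounds are considered here, and "the series" means these few. Any claim that something is new, unique, unknown or untested is made for them only; others in the source may bear on it.

Of the compounds shown here, three have been measured in a functional assay for antagonist activity at Alpha-1A adrenergic receptor (Oryctolagus cuniculus); on this read-out higher numbers stand for weaker binding and lower numbers for tighter binding. Compound 1 `COc1ccccc1N1CCN(CCCNc2nc(C)cc(C)c2C(N)=O)CC1` gives 10 nM in this assay. Compound 2 `COc1ccccc1N1CCN(CCCNc2cncnc2C(=O)N(C)C)CC1` gives 3.98 nM. Compound 3 `CN(C)C(=O)c1cccnc1NCCCN1CCN(c2ccccc2C#N)CC1` gives 2 nM, the lowest of the three numbers; its gap to compound 2 lies within the usual scatter, while its gap to compound 1 lies beyond it, so compound 3 can be said to bind more tightly than compound 1 but not to be separated from compound 2.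

The next compound, compound 4 `CC(C)c1ccccc1N1CCN(CCCNc2ncccc2C(=O)N(C)C)CC1`, differs from compound 3 in a single place: isopropyl in place of cyano on an aromatic carbon. Everything else, including the shared core and the three-carbon chain linking it to the piperazine, stays the same.

Within the data shown here, no pair of measured compounds differing in just one place is available here, so the size of this step cannot be read from any measured comparison. Among the measured compounds shown here, the three measured values do fall within a narrow band, which suggests that the outer aryl substituent is not the only thing setting the number. Compound 4 is expected to give 5 nM, within a range of 1.2 nM to 20 nM, which means an estimated step of a 2.5-fold higher number from compound 3 to compound 4 (0.40 log units; beyond the scatter) that is modest and likely within the scatter, tilted toward a slightly higher number.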

Compound 4, dissociation constant: 0.398 nM
For compound 4 the middle estimate is 13-fold (1.10 log units) above the measured one; measured number below the stated range.
By their numbers in this assay, from the lowest: compound 4; then compounds 3 and 2 (each within the scatter of the next); then compound 1.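

Among these compounds, this pair gives the first reading of a single change: in this assay, putting isopropyl in place of cyano on the aromatic carbon ortho to a large group gives a 5.0-fold lower number from compound 3 to compound 4 (0.70 log units; beyond the scatter). The group at this place does move the number, and the move lies beyond the usual scatter of repeated measurements. The change also shows that a nitrile, with its triple bond and one hydrogen-bond acceptor, is not needed here for a low number, since isopropyl has three carbon atoms, no hydrogen-bond acceptor and still gives the lower value on the same core. Nothing measured here accounts for why the number falls with this swap, so the step stands as an observation without an explanation.

A single pair cannot separate the contributions of size, shape and the loss of the acceptor, and groups such as ethyl, tert-butyl, cyclopropyl or chloro at the same place would be needed to show which of these tracks the number. As far as these compounds go, it also remains open whether isopropyl would give a similar step on a different core, or with a longer chain leading to the piperazine.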